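This account rests on a few compounds, and the source may have more. Where it says the series, first, only, none or still open, it means among the compounds named here.

Compound 1 `Cc1nc2c(CCc3ccccc3)cccn2c1N` gives 71% in a functional assay on the whole organism with Canis familiaris (Canis lupus familiaris) as the target, at a dose of 2 mg/kg by the intravenous route; on this read-out higher numbers stand for a stronger effect at the one dose given and lower numbers for a weaker effect.
Compound 2 `Cc1nc2c(OCc3ccccc3)cccn2c1NC=O` gives 3% in this assay.

Compound 1 stands highest of the two numbers; compound 2 lies far lower, a gap well beyond the scatter. The step considered here leads from compound 1 to compound 3 `COC(=O)c1c(C)nc2c(CCc3ccccc3)cccn12`, which has not yet been measured. The change is methoxycarbonyl in place of amino on an aromatic carbon. Among the compounds with values here, no measured pair shows this kind of change, so the expectation rests only on the two numbers above. The step is expected to be a loss beyond the scatter, as a number 36 percentage points lower from compound 1 to compound 3 (beyond the scatter). Compound 3 is therefore estimated at 35%, in a range from 5% to 70%.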

Compound 3, a percentage reported as inhibition, in the whole organism at one dose (the size of the read-out at that dose, not a potency): 6%
Compound 3: the middle estimate sits 29 percentage points above what was measured; measured number inside the range.
By their numbers in this assay, from the lowest: compounds 2 and 3 (each within the scatter of the next); then compound 1.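

In this assay, within the data shown here, methoxycarbonyl in place of amino on this aromatic carbon brings a number 65 percentage points lower from compound 1 to compound 3 (beyond the scatter), the first change in a single place that can be read. With the rest of compound 1 kept the same, the effect at this one dose clearly depends on the group at this carbon. No measurement here explains the size of this loss.

The compounds shown leave open how other groups would fare at this carbon. A methylamino group, a hydroxyl group or a carboxylic acid would show whether the amino group itself is special.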